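A few compounds are considered here, and "the series" means these few. Any claim that something is new, unique, unknown or untested is made for them only; others in the source may bear on it.

Values in a physicochemical assay for solubility, using the shake flask method, in simulated intestinal fluid, measured as kinetic solubility, with a stated time of 20 h, at pH 6.5; on this read-out higher numbers stand for higher solubility and lower numbers for lower solubility:
- Compound 1 `Fc1ccc(-c2nc3cnc(Nc4ccccn4)cc3[nH]2)cc1F`: >= 50000 nM
- Compound 2 `Fc1ccc(-c2nc3cnc(Nc4ccc(C(F)(F)F)cn4)cc3[nH]2)cc1F`: >= 50000 nM
- Compound 3 `FC(F)(F)c1cccc(-c2nc3cnc(Nc4ccc(-c5nnn[nH]5)cn4)cc3[nH]2)c1`: < 5000 nM

Each of these three values is a limit of this assay and not a number. Compound 2 sits at the limit of >= 50000 nM in this assay, at which 2 of the 3 values shown sit. Compound 3 sits at the limit of < 5000 nM in this assay, at which 1 of the 3 values shown sits.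

The account follows the step from compound 2 to compound 4 `FC(F)(F)c1ccc(Nc2cc3[nH]c(C4CCOC4)nc3cn2)nc1`, which has oxolan-3-yl in place of 3,4-difluorophenyl on an aromatic carbon. For the measured compounds named here, no measured step covers this exchange. Going by the values given here, the only one available is a step that the two limits leave unreadable from compound 1 to compound 2, where trifluoromethyl takes the place of hydrogen on an aromatic carbon, and it offers no size to carry over. Compound 2 provides a limit rather than a number as the starting point, so no change beyond the usual scatter is expected in this assay, and no direction can be favoured. The estimated step is an at least 1.1-fold lower number from compound 2 to compound 4 (0.04 log units; that floor lies within the scatter). The value expected for compound 4 is 45000 nM, with an estimated range from 20000 nM to 50000 nM.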

Compound 4, solubility: 180000 nM
The estimate for compound 4 lay 4.0-fold (0.60 log units) below the measured number, and the stated range ends below it.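

No step can be read from compound 2 to compound 4 in this assay. Compound 2 gives >= 50000 nM, which is a limit of the assay and not a number. The compounds shown leave open how large a change oxolan-3-yl in place of 3,4-difluorophenyl brings in this assay.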